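A few compounds are considered here, and "the series" means these few. Any claim that something is new, unique, unknown or untested is made for them only; others in the source may bear on it.

Compound 3 `c1ccc(-c2cc3nn(-c4ccccc4)cc3cn2)cc1` gives the lowest of the three numbers in a functional assay on MCF7 cells (Homo sapiens) for inhibition, read by fluorescence, with a stated time of 72 h (a lower number here means a stronger inhibitor of growth, a higher number a weaker inhibitor of growth), at 4800 nM. Compound 1 `c1ccc(-n2cc3cnc(-c4ccsc4)cc3n2)cc1` gives 9800 nM and compound 2 `CCCCc1cc2nn(-c3ccccc3)cc2cn1` gives 13300 nM. The measured steps are a 2.0-fold lower number from compound 1 to compound 3 (0.31 log units; beyond the scatter), a 2.8-fold lower number from compound 2 to compound 3 (0.44 log units; beyond the scatter) and a 1.4-fold higher number from compound 1 to compound 2 (0.13 log units; within the scatter), each a change on an aromatic carbon of the shared core. Compound 4 `Cn1cc2cnc(-c3ccccc3)cc2n1` differs from compound 3 by methyl in place of phenyl on an aromatic nitrogen. Going by the values given here, no measured step touches the aromatic nitrogen, so none of the three steps bears on this change and no direction can be read from them. With the phenyl on that nitrogen present in every measured compound, a weaker inhibitor of growth is expected rather than a stronger one, with a wide range. Compound 4 is estimated at 12000 nM in this assay, range 3000 nM to 50000 nM, which means an expected 2.5-fold higher number from compound 3 to compound 4 (0.40 log units; beyond the scatter).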

Compound 4, concentration for 50% growth inhibition: > 100000 nM
Compound 4 was reported as a limit; the forecaster's own chance of this, stated with the estimate: 15%; middle value at least 8.3-fold (0.92 log units) away from the limit.
By their numbers in this assay, from the lowest: compound 3; then compounds 1 and 2 (each within the scatter of the next). At a limit, above all of these: compound 4.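

Compound 4 is reported in this assay only as a limit, > 100000 nM: the limit of > 100000 nM in this assay, at which 1 of the 4 values shown sits.

Methyl in place of phenyl on the aromatic nitrogen gives an at least 20-fold higher number from compound 3 to compound 4 (1.31 log units; beyond the scatter), the first measured step at this position and the only large one in the series, so growth inhibition in this set depends strongly on the group held there.

The compounds shown leave open whether a cyclohexyl, a benzyl or a longer chain on that nitrogen would keep the activity of compound 3. Also open, as far as these compounds go, is whether a phenyl carrying an amine or a carboxylic acid would lower the number.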